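Removing the chloro group on the road from compound 2 to compound 3

The compounds below may be only part of what the source reports. "The series", "measured", "known", "first", "only" and "open" are said of these compounds alone.

Measured so far:
- compound 1 `O=[N+]([O-])c1ccccc1CNc1cccc2[nH]ncc12`: 65%
- compound 2 `O=[N+]([O-])c1ccc(Cl)cc1CNc1cc(C(F)(F)F)cc2[nH]ncc12`: 65%

In an assay for inhibition of Indoleamine 2,3-dioxygenase 1 (Homo sapiens), with stated times of 10 min and 60 min, tested at 100 uM (on this read-out higher numbers stand for a stronger effect at the one concentration tested and lower numbers for a weaker effect), compound 1 gives 65%. In this assay compound 2 gives 65%, which is level with compound 1 at the digits shown; the two values lie within the usual scatter of each other, so nothing can be said about which of them sits higher. Compound 2 carries both a chloro group and a trifluoromethyl group that compound 1 lacks, and yet the read-out is unchanged.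

The step now under consideration leads from compound 2 to the unmeasured compound 3 `O=[N+]([O-])c1ccccc1CNc1cc(C(F)(F)F)cc2[nH]ncc12`. The structural change is hydrogen in place of chloro on an aromatic carbon. Compound 3 thus keeps the trifluoromethyl group of compound 2 and drops only the chloro group.

Since compound 1, which lacks both groups, and compound 2, which carries both, give the same read-out in this assay, no effect beyond the scatter is expected from dropping the chloro group alone. For compound 3 the expected step is no change at the digits printed from compound 2 to compound 3 (within the scatter), none beyond the scatter. Compound 3 is therefore estimated at 65%, with a range from 50% to 78%.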

Compound 3, a percentage reported as inhibition, at one concentration (the size of the read-out at that concentration, not a potency): 76%
For compound 3 the middle estimate is 11 percentage points below the measured one, within the range that was stated.
By their numbers in this assay, from the lowest: compounds 1 and 2 (each within the scatter of the next); then compound 3.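

In this assay, for the compounds shown here, hydrogen in place of chloro on the aromatic carbon para to a nitro group gives a number 11 percentage points higher from compound 2 to compound 3 (beyond the scatter) and so shows that this position does matter to the read-out, which the earlier compounds alone could not show. Trifluoromethyl in place of hydrogen on an aromatic carbon gives a number 11 percentage points higher from compound 1 to compound 3 (beyond the scatter) and so has a visible effect of its own, and together these single changes show that the level read-outs of the two earlier compounds do not mean that both groups are without effect: the higher number goes with the trifluoromethyl group when the chloro group is absent. No measurement at hand says why either change moves the read-out.

As far as these compounds go, whether another group at this position, such as a methoxy group, an amine or a carboxylic acid, would take the number above, below or level with that of compound 3 stays open. The read-out at one concentration also leaves open how the potency of compound 3 relates to that of the other two compounds.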